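The source may report more compounds than this note shows. Statements on the series, on what has been measured and on what is new or still open speak of the compounds shown alone.

Series notes. Compound 1 `O=[N+]([O-])c1c(CS(=O)(=O)c2ccccc2)nc2c(-c3cccc(CO)c3)cc(Cl)cn12` and compound 2 `O=[N+]([O-])c1c(CS(=O)(=O)c2ccccc2)nc2c(-c3cccc(F)c3)cc(Cl)cn12` share one core and are both read in an ADME assay on HepG2 cells (Homo sapiens) for cytotoxicity, read by MTT assay, with a stated time of 72 h; on this read-out higher numbers stand for lower toxicity in this test and lower numbers for higher toxicity in this test. In this assay compound 1 gives > 25000 nM, which is a limit of the assay and not a number. In this assay compound 2 gives > 12500 nM, again a limit of the assay rather than a number. Among the compounds with values here, the one measured step is a step that the two limits leave unreadable from compound 1 to compound 2, unreadable because the limit of > 25000 nM in this assay, at which 1 of the 2 values shown sits, and the limit of > 12500 nM in this assay, at which 1 of the 2 values shown sits, bracket the two values. Compound 2 therefore stands at a limit in this assay, with no number of its own and no readable step leading to it.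

Compound 3 `O=[N+]([O-])c1c(CS(=O)(=O)c2ccccc2)nc2c(-c3cccnc3)cc(Cl)cn12` differs from compound 2 in one place: pyridin-3-yl in place of 3-fluorophenyl on an aromatic carbon. The exchange sits at the same position as the measured step, which lies between two limits and so gives no size to carry over into this assay. With both measured values at limits, no step beyond the scatter is expected from this exchange; the change expected in this assay is a step that the limit leaves unreadable from compound 2 to compound 3. Compound 3 is thus estimated at 25000 nM in this assay, within 8000 nM to 60000 nM, and most likely reported once more as a limit only.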

Compound 3, half-maximal cytotoxic concentration: > 31300 nM
Compound 3: only a limit was reported (the forecaster's own chance of this, stated with the estimate: 80%); at least 1.2-fold (0.09 log units) between middle value and limit.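

In this assay compound 3 gives > 31300 nM, a limit of the assay and not a number. Within the data shown here, with compound 1, compound 2 and compound 3 all standing at limits, no step among them can be read. The compounds shown leave open whether 3-(hydroxymethyl)phenyl, 3-fluorophenyl and pyridin-3-yl differ at all in this read-out.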